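Swapping thiophen-2-yl for iodo on a weak nucleoside

The source may report more compounds than this note shows. Statements on the series, on what has been measured and on what is new or still open speak of the compounds shown alone.

Values in a functional assay on HL-60 cells (Homo sapiens) for antiproliferative activity, read by XTT assay, with a stated time of 72 h; a lower number here means a stronger inhibitor, a higher number a weaker inhibitor:
compound 1 `CSc1ncnc2c1c(-c1cccs1)cn2[C@@H]1O[C@H](CO)[C@@H](O)[C@H]1O` 1130 nM
compound 2 `CNc1ncnc2c1c(-c1cccs1)cn2[C@@H]1O[C@H](CO)[C@@H](O)[C@H]1O` > 20000 nM (a limit of the assay)
compound 3 `Cc1ncnc2c1c(-c1cccs1)cn2[C@@H]1O[C@H](CO)[C@@H](O)[C@H]1O` 5730 nM

Compound 3 gives 5730 nM, the higher of the two results that are true numbers. The nearest gap is a 5.1-fold higher number from compound 1 to compound 3 (0.71 log units; beyond the scatter). Compound 2 gives > 20000 nM, which is a limit of the assay. The remaining steps are an at least 17-fold higher number from compound 1 to compound 2 (1.24 log units; beyond the scatter) and an at least 3.4-fold lower number from compound 2 to compound 3 (0.54 log units; beyond the scatter).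

The next compound is compound 4 `Cc1ncnc2c1c(I)cn2[C@@H]1O[C@H](CO)[C@@H](O)[C@H]1O`, which keeps the methyl group of compound 3 and differs at another place: iodo in place of thiophen-2-yl on an aromatic carbon. So compound 4 carries iodo where compound 3 carries thiophen-2-yl.

All three measured steps exchange methylsulfanyl, methylamino and methyl, and thiophen-2-yl stays in every one of them. They show that this assay responds to changes on the shared core, but none of them touches this place, so they offer neither a size nor a direction for the new step. No step beyond the scatter is therefore expected, though with wide uncertainty in either direction. The expected change is a 1.4-fold lower number from compound 3 to compound 4 (0.16 log units; within the scatter). For compound 4 the estimated value is 4000 nM, with an expected range of 500 nM to 20000 nM.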

Compound 4, half-maximal inhibitory concentration: 2650 nM
Compound 4: middle estimate off by 1.5-fold (0.18 log units), on the high side; low and high end bracket the measured number.
By their numbers in this assay, from the lowest: compound 1; then compound 4; then compound 3. At a limit, above all of these: compound 2.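

In this assay, the only change shown at this place gives a 2.2-fold lower number from compound 3 to compound 4 (0.33 log units; beyond the scatter). This shows that the aromatic carbon bearing thiophen-2-yl is not silent in this assay, and that the five-membered aromatic ring is not needed to hold the level of compound 3: iodo, with 1 heavy atom and no ring, gives a modestly lower number than the 5 heavy atoms it replaces. The compounds show the direction and size of this one exchange on the methyl-bearing core, but nothing given here bears on why the number falls.

As far as these compounds go, it remains open whether iodo in place of thiophen-2-yl would give a step of similar size and direction with the methylsulfanyl group of compound 1 or the methylamino group of compound 2. From the compounds shown here alone, it is also open how this position would respond to chloro, a phenyl ring, an amine or a longer chain, so a single exchange does not yet describe what the position tolerates.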